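From benzoyl to (2-oxopropyl)carbonyl on a shared core

The source may hold more compounds than are shown below. What is called first, only, known or untested is meant among the compounds shown, and "the series" means these compounds.

Measured so far in a functional assay on Ehrlich cells (Mus musculus) for cytotoxicity, read by trypan blue exclusion, with a stated time of 2 h (on this read-out higher numbers stand for weaker inhibition and lower numbers for stronger inhibition), for three compounds:
- compound 1 `N#CC1=C(NC(=O)c2ccccc2)N(c2ccc(S(N)(=O)=O)cc2)C2=C(C(=O)CCC2)C1c1ccc(Cl)cc1Cl` gives 10 ug/mL as a number
- compound 2 `NC(=O)C1=C(N)N(c2ccc(S(N)(=O)=O)cc2)C2=C(C(=O)CCC2)C1c1ccc(Cl)cc1Cl` gives > 100 ug/mL as a limit of the assay, not a number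
- compound 3 `CN(C)c1ccc(/C=C/C=N/C2=C(C#N)C(c3ccc(Cl)cc3Cl)C3=C(CCCC3=O)N2c2ccc(S(N)(=O)=O)cc2)cc1` gives > 100 ug/mL as a limit of the assay, not a number

Among the compounds with values here, compound 1 stands alone as the only compound with a real number, while compound 2 and compound 3 each reach only a limit.

Compound 4 `CC(=O)CC(=O)NC1=C(C#N)C(c2ccc(Cl)cc2Cl)C2=C(CCCC2=O)N1c1ccc(S(N)(=O)=O)cc1` keeps the core of compound 1 but has 2-oxopropyl in place of phenyl on a carbonyl carbon, so that benzamido becomes ((2-oxopropyl)carbonyl)amino. Within the data shown here, no pair of measured compounds shows this change on its own. Among the measured compounds shown here, compound 1 at 10 ug/mL is the single number to start from. The expectation leans toward weaker inhibition because of the limit of > 100 ug/mL in this assay, at which 2 of the 3 values shown sit, in the data so far. In this assay the expected move runs in that direction, an estimated 3.0-fold higher number from compound 1 to compound 4 (0.48 log units; beyond the scatter) in size. Compound 4 is estimated at 30 ug/mL with an expected range from 10 ug/mL to 100 ug/mL in this measurement.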

Compound 4, half-maximal inhibitory concentration: 64 ug/mL
Compound 4: the middle estimate sits 2.1-fold (0.33 log units) below what was measured; low and high end bracket the measured number.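

In this assay, within the data shown here, putting 2-oxopropyl in place of phenyl on a carbonyl carbon gives a 6.4-fold higher number from compound 1 to compound 4 (0.81 log units; beyond the scatter), the first comparison here in which the compounds differ in only one place. At this position, then, the benzoyl group goes with stronger inhibition than the open-chain (2-oxopropyl)carbonyl group, although the aromatic ring is not needed for a measurable result. Compound 4 still gives a real number rather than a limit, which is not a given here: the limit of > 100 ug/mL in this assay, at which 2 of the 4 values shown sit.

With only these two groups to compare, the effect of losing the aromatic ring cannot be separated from the effect of gaining the oxygen of 2-oxopropyl. A plain propyl chain on the same carbonyl carbon could help to separate them, while a methoxyphenyl group would show how far the ring itself can be varied.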